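The source may hold more compounds than are shown below. What is called first, only, known or untested is meant among the compounds shown, and "the series" means these compounds.

Measured compounds:
compound 1 `Cc1c(Nc2nc(N)c3c(C#N)c(N4CCC[C@H]4C)n(C)c3n2)cnn1C`: 43 nM
compound 2 `C[C@@H]1CCCN1c1c(C#N)c2c(N)nc(N)nc2n1C`: 217 nM
compound 3 `C[C@@H]1CCCN1c1c(C#N)c2c(N)nc(Nc3cnn(C)c3)nc2n1C`: 5 nM

In an assay on isolated protein for inhibition of Leucine-rich repeat serine/threonine-protein kinase 2 variant G2019S (Homo sapiens), read by TR-FRET and LanthaScreen, with stated times of 50 min and 30 min, in the presence of a further agent that is not named here (a higher number here means a weaker inhibitor, a lower number a stronger inhibitor), compound 3 stands lowest of the three numbers. Its nearest neighbour is compound 1, as seen in an 8.6-fold lower number from compound 1 to compound 3 (0.93 log units; beyond the scatter); the furthest is compound 2, as seen in a 43-fold lower number from compound 2 to compound 3 (1.64 log units; beyond the scatter). The step of a 5.0-fold higher number from compound 1 to compound 2 (0.70 log units; beyond the scatter) shows what removing the pyrazole from the shared core costs when that ring carries a methyl on an aromatic carbon.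

Compound 4 `C[C@@H]1CCCN1c1c(C#N)c2c(N)nc(Nc3cn(C)nc3C(F)(F)F)nc2n1C` differs from compound 3 by trifluoromethyl in place of hydrogen on an aromatic carbon, a substituent on a carbon of the pyrazole ring, next to the ring nitrogen and two ring bonds from the ring atom that bears a methyl group.

The step that bears most directly on this change is the pair compound 3 and compound 1, in which a methyl on an aromatic carbon of the same pyrazole ring was the only difference and raised the number, as given by an 8.6-fold lower number from compound 1 to compound 3 (0.93 log units; beyond the scatter). The step from compound 2 to compound 3 shows the unsubstituted pyrazole itself is the main driver. A substituent on a carbon of that ring is therefore expected to weaken inhibition again, by a modest step in this assay, rather than improve it.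

Compound 4 is therefore expected to give 35 nM in this assay, in the range 8 nM to 150 nM, which corresponds to an expected step of a 7.0-fold higher number from compound 3 to compound 4 (0.85 log units; beyond the scatter).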

Compound 4, half-maximal inhibitory concentration: 358 nM
The estimate for compound 4 lay 10-fold (1.01 log units) below the measured number, and the stated range ends below it.
By their numbers in this assay, from the lowest: compound 3; then compound 1; then compounds 2 and 4 (each within the scatter of the next).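

In this assay a trifluoromethyl on this aromatic carbon of the pyrazole, two ring bonds from the ring atom that bears a methyl group, carries a large cost (a 72-fold higher number from compound 3 to compound 4 (1.85 log units; beyond the scatter)), and this cost cancels what the pyrazole gave. With 1-methyl-3-(trifluoromethyl)-1H-pyrazol-4-yl on the nitrogen, the compound cannot be told apart from the one with hydrogen there (a 1.6-fold higher number from compound 2 to compound 4 (0.22 log units; within the scatter)), so a pyrazole on that nitrogen is not enough by itself and its carbon substitution decides the outcome. The comparison with the other substituted pyrazole (an 8.3-fold higher number from compound 1 to compound 4 (0.92 log units; beyond the scatter)) changes both the group and the ring carbon it sits on, so it does not separate the two, and no measurement here bears on the origin of the loss.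

From the compounds shown here alone, it remains open whether the loss belongs to trifluoromethyl itself or to any group on this carbon; a methyl, a chlorine atom or a methoxy group here would separate the two. Also open, going by these compounds, is how a trifluoromethyl, or an amine, would behave on the carbon that carries the second methyl of 1,5-dimethyl-1H-pyrazol-4-yl.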